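The compounds below may be only part of what the source reports. "The series", "measured", "known", "first", "only" and "open" are said of these compounds alone.

Compound 1 `CCOc1ccc(F)cc1C(C)NC(=O)N(C)S(=O)(=O)c1ccccc1` and compound 3 `COc1ccc(F)cc1C(C)NC(=O)N(C)S(=O)(=O)c1ccc(Cl)cc1` belong to the same study; in a functional assay on thoracic aorta (Rattus norvegicus, strain Wistar), with a stated time of 15 min (on this read-out lower numbers stand for an effect already at smaller amounts and higher numbers for an effect only at larger amounts of compound), compound 1 gives 11500 nM, and compound 3 gives 12600 nM, two values that lie within the scatter of each other. Compound 2 `COc1ccc(OC)c(CNC(=O)NS(=O)(=O)c2ccccc2)c1` stands apart, since for compound 2 this assay reports only a limit, > 300000 nM, and no number. That limit is the one recorded as the limit of > 300000 nM in this assay, at which 1 of the 3 values shown sits. Compound 4 `COc1ccc(OC)c(CNC(=O)NS(=O)(=O)c2ccc(C)cc2)c1` differs from compound 2 by a single change, (methyl in place of hydrogen on an aromatic carbon). Among the compounds with values here, no measured pair in the set isolates this change, so no step is known for it. Compound 4 is expected to remain near the limit, with a step of an at least 1.2-fold lower number from compound 2 to compound 4 (0.07 log units; that floor lies within the scatter) that stays within the scatter. The estimate for compound 4 in this assay is 250000 nM, ranging from 60000 nM to 900000 nM.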

Compound 4, half-maximal effective concentration: > 300000 nM
Compound 4 ended at the assay's limit; the forecaster's own chance of this, stated with the estimate: 70%; middle value at least 1.2-fold (0.07 log units) away from the limit.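

Compound 2 and compound 4 both stand only at a limit, so no step can be read for the change from phenyl to 4-methylphenyl: the limit of > 300000 nM in this assay, at which 2 of the 4 values shown sit.

The compounds shown leave open whether this methyl alters the response at all, and how far either compound lies beyond that limit.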